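Cytotoxicity on Vero cells: from compound 1 to compound 4

The compounds below may be only part of what the source reports. "The series", "measured", "known", "first", "only" and "open" are said of these compounds alone.

The series shares one core, carried by compound 1 `COc1ccc(-n2c(SC(C)C(=O)Nc3nc(C)c(Br)cc3Br)nc3ccccc32)cc1`, compound 2 `CCOc1ccc(-n2c(SC(C)C(=O)Nc3cc(C)cc(C)n3)nc3ccccc32)cc1` and compound 3 `COc1ccc(Cn2c(NC(C)C(=O)Nc3ccc(C)cc3Cl)nc3ccccc32)cc1`. In an ADME assay on Vero cells (Chlorocebus sabaeus) for cytotoxicity, read by MTT assay, with a stated time of 24 h (a higher number here means that more compound is tolerated, a lower number that less compound is tolerated), compound 1 gives 9700 nM. For the measured compounds named here, that is the only number in hand: in this assay compound 2 gives "not determined" (no result reported) and compound 3 gives "not determined" (no result reported), so compound 1 cannot be ranked against either of them, and no measured pair shows how a single structural change moves this read-out.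

The next entry is compound 4 `COc1ccc(-n2c(SC(C)C(=O)Nc3ncc(C)cc3Cl)nc3ccccc32)cc1`. Against compound 1 the difference is 3-chloro-5-methylpyridin-2-yl in place of 3,5-dibromo-6-methylpyridin-2-yl on an amide-type nitrogen, on the amide-type nitrogen whose other neighbour is the carbonyl carbon. Nothing measured in the series tells how exchanging one substituted pyridin-2-yl for another affects tolerance on Vero cells.

Going by the values given here, with no measured step to lean on, the expectation is that the change from compound 1 to compound 4 stays within the usual scatter of this assay, with no direction claimed. The step of a 1.2-fold higher number from compound 1 to compound 4 (0.09 log units; within the scatter) is the estimated size of that move. For compound 4 the estimate in this assay is 12000 nM, expected to fall between 4000 nM and 40000 nM, with the measured result for compound 4 to follow.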

Compound 4, half-maximal cytotoxic concentration: 880 nM
Compound 4: the middle estimate sits 14-fold (1.13 log units) above what was measured; measured number below the stated range.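

In this assay, for the compounds shown here, an 11-fold lower number from compound 1 to compound 4 (1.04 log units; beyond the scatter) is the first readable step, and it shows that tolerance responds strongly to the substituted pyridin-2-yl on the amide-type nitrogen whose other neighbour is the carbonyl carbon, with 3-chloro-5-methylpyridin-2-yl tolerated at lower concentrations than 3,5-dibromo-6-methylpyridin-2-yl. The counted features of the two groups stay close: each is one six-membered aromatic ring with 1 hetero atom, with 0 hydrogen-bond donors, 1 hydrogen-bond acceptor and no net charge, so a large move here does not require a change of ring type, charge or hydrogen-bond count. No measurement available here accounts for the size or direction of this step.

This single pair changes the halogens and the methyl placement together, so it leaves open how much of the step belongs to each of these differences. Also open, from the compounds shown here alone, is how the read-out would respond at this same place to a pyridin-2-yl carrying an amine or a carboxylic acid, and whether the step would hold on the other parts of the series.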